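A large group replaces methyl on an aromatic nitrogen

This account rests on a few compounds, and the source may have more. Where it says the series, first, only, none or still open, it means among the compounds named here.

In an in vitro ADME assay on microsomes (Mus musculus) for metabolic stability (on this read-out higher numbers stand for a longer-lived compound and lower numbers for a shorter-lived compound), compound 1 `CNC(=O)Nc1ccc(-c2nc(N3CC4CCC(C3)O4)c3cnn(C)c3n2)cc1` gives > 0.5 h, which is a limit and not a number. Its standing among the measured compounds therefore cannot be ranked. Compound 2 `O=C(Nc1ccccc1)Nc1ccc(-c2nc(N3CC4CCC(C3)O4)c3cnn(C4CCC5(CC4)OCCO5)c3n2)cc1` differs from compound 1 in more than one place. Compound 2 gives > 0.5 h, also a limit. Compound 3 `O=C(Nc1ccncc1)Nc1ccc(-c2nc(N3CC4CCC(C3)O4)c3cnn(C4CCC5(CC4)OCCO5)c3n2)cc1` gives > 0.5 h, again a limit. The whole picture so far is the limit of > 0.5 h in this assay, at which 3 of the 3 values shown sit.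

Compound 4 `CNC(=O)Nc1ccc(-c2nc(N3CC4CCC(C3)O4)c3cnn(C4CCC5(CC4)OCCCO5)c3n2)cc1` changes compound 1 in one place: a group of 11 heavy atoms (9 carbon, 2 oxygen; one six-membered non-aromatic ring of carbon only, one six-membered non-aromatic ring with 2 hetero atoms) in place of one carbon atom, on an aromatic nitrogen. Among the measured compounds shown here, the only measured step, a step that the two limits leave unreadable from compound 2 to compound 3, puts pyridin-4-yl in place of phenyl on an amide-type nitrogen, so it is a different change and offers no size to borrow. Compound 2 and compound 3 do carry a large group of their own on that aromatic nitrogen, and both readings stop at the limit. With no readable step to go on, no direction can be argued, and no step beyond the scatter is expected in this assay. The expected step that the limit leaves unreadable from compound 1 to compound 4 is only a rough estimate. For compound 4 the estimated half-life is 0.7 h, with an expected range of 0.3 h to 1.5 h, and another reading at the limit is quite likely.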

Compound 4, half-life: > 0.5 h
Compound 4: no number, only a limit (the forecaster's own chance of this, stated with the estimate: 70%); the middle value lies beyond the limit too.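

Compound 1 and compound 4 both give a limit rather than a number in this assay, so the step between them cannot be read, and the picture stays as it was: the limit of > 0.5 h in this assay, at which 4 of the 4 values shown sit.

The compounds shown leave open how long each one actually lasts, and whether swapping methyl for the large group on the aromatic nitrogen changes the half-life at all.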